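Arylthio enone series: growth inhibition in prostate carcinoma cells

The source may report more compounds than this note shows. Statements on the series, on what has been measured and on what is new or still open speak of the compounds shown alone.

Measured so far:
compound 1 `COc1ccccc1/C=C(/Sc1ccc(C)cc1)C(=O)c1ccc(Cl)cc1` — 25000 nM
compound 2 `COc1ccccc1/C=C(/SCc1ccc(F)cc1)C(=O)c1ccc(Br)cc1` — 10000 nM
compound 3 `Cc1ccc(S/C(=C/c2ccc(F)c(C)c2)C(=O)c2ccc(Br)cc2)cc1` — 25000 nM

In a functional assay on DU-145 cells (Homo sapiens) for inhibition, read by trypan blue exclusion, with a stated time of 96 h (on this read-out lower numbers stand for stronger inhibition of growth and higher numbers for weaker inhibition of growth), compound 3 gives 25000 nM, level with compound 1 at the digits shown and with it the highest of the three numbers; the difference to compound 1 is within the scatter, while compound 2 at 10000 nM stands a clear step lower, beyond the scatter.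

Compound 4 `COc1ccccc1/C=C(/Sc1ccc(C)cc1)C(=O)c1ccc(Br)cc1` has not been measured in this assay. It differs from compound 3 as follows: 2-methoxyphenyl in place of 4-fluoro-3-methylphenyl on a double-bonded chain carbon bound to a double-bonded chain carbon. Compound 1, which also carries 2-methoxyphenyl at that place, gives 25000 nM in this assay, so no large movement is expected from the exchange itself. The step from compound 3 to compound 4 is expected to be small, no change at the digits printed from compound 3 to compound 4 (within the scatter), in no clear direction and probably inside the scatter. Compound 4 is therefore estimated at 25000 nM, with a plausible range of 10000 nM to 60000 nM.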

Compound 4, concentration for 50% growth inhibition: 9000 nM
Beside the measured number, compound 4's estimate is 2.8-fold (0.44 log units) above it; measured number outside the range, below it.
By their numbers in this assay, from the lowest: compounds 4 and 2 (each within the scatter of the next); then compounds 1 and 3 (each within the scatter of the next).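

In this assay, 2-methoxyphenyl in place of 4-fluoro-3-methylphenyl on a double-bonded chain carbon bound to a double-bonded chain carbon is not a neutral exchange: the series shows a 2.8-fold lower number from compound 3 to compound 4 (0.44 log units; beyond the scatter), with bromo on the aromatic carbon and 4-methylphenyl on the sulfur held fixed. The halogen also matters with 2-methoxyphenyl in place, since bromo in place of chloro on an aromatic carbon gives a 2.8-fold lower number from compound 1 to compound 4 (0.44 log units; beyond the scatter). By contrast, 4-methylphenyl in place of 4-fluorobenzyl on a sulfur gives a 1.1-fold lower number from compound 2 to compound 4 (0.05 log units; within the scatter), a step within the scatter, so this exchange shows no clear effect here.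

Going by these compounds, whether the aryl step holds with chloro, and whether an amine or a carboxylic acid in place of bromo would move the number, stays open. Nothing available here explains the size of either step beyond the scatter.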